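Replacing a Benzyloxy Thioester with a Propyl Thioester

This account rests on a few compounds, and the source may have more. Where it says the series, first, only, none or still open, it means among the compounds named here.

Of the compounds shown here, three built on a shared core have been tested in a functional assay on A549 cells (Homo sapiens) for inhibition, read by MTT assay, with a stated time of 96 h; on this read-out higher numbers stand for weaker inhibition of growth and lower numbers for stronger inhibition of growth. Compound 1 `O=C(NCCCCCCSSCCCCCCNC(=O)c1cc(-c2ccncc2)n[nH]1)c1cc(-c2ccncc2)n[nH]1` gives 6070 nM. Compound 2 `C=CCOC(=O)SCCCCCCNC(=O)c1cc(-c2ccncc2)n[nH]1` gives 15200 nM in this assay, and compound 3 `O=C(OCc1ccccc1)SCCCCCCNC(=O)c1cc(-c2ccncc2)n[nH]1` gives 13400 nM. Among these three numbers compound 3 stands second highest; compound 2 is nearest, within the scatter, while compound 1 is furthest away, with that gap lying beyond the scatter. Among the compounds with values here, the only one-place step in the set, a 1.1-fold lower number from compound 2 to compound 3 (0.05 log units; within the scatter), is within the scatter.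

Compound 4 `CCCC(=O)SCCCCCCNC(=O)c1cc(-c2ccncc2)n[nH]1` has not yet been measured. It differs from compound 3 thus: propyl in place of benzyloxy on a carbonyl carbon. Within the data shown here, no measured step touches the carbonyl carbon bound to sulfur; the one step available altered the group on a saturated chain carbon bound to an oxygen next to a carbonyl group and stayed within the scatter. In this assay a step of no more than that size is therefore expected, a 1.1-fold lower number from compound 3 to compound 4 (0.05 log units; within the scatter). Compound 4 is estimated at 12000 nM, with a range from 5000 nM to 30000 nM.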

Compound 4, concentration for 50% growth inhibition: 15100 nM
Estimate against measurement, compound 4: 1.3-fold (0.10 log units) below, and the stated range covers the measured number.
By their numbers in this assay, from the lowest: compound 1; then compounds 3, 4 and 2 (each within the scatter of the next).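

In this assay, the carbonyl carbon bound to sulfur now has measured steps of its own: a 1.1-fold higher number from compound 3 to compound 4 (0.05 log units; within the scatter) and a 1.0-fold lower number from compound 2 to compound 4 (0.00 log units; within the scatter). Neither propyl in place of benzyloxy nor propyl in place of allyloxy moves the number beyond the scatter, so at this place the read-out does not separate propyl, which has no ring and no hydrogen-bond acceptor, from benzyloxy, which carries a six-membered aromatic ring and a hydrogen-bond acceptor. Nothing available accounts for how closely these numbers sit together. The compounds shown leave open whether an amine, a carboxylic acid or a longer chain on this carbonyl carbon would give a number beyond the scatter of these. They also leave open whether the same holds in any other cell line.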